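A few compounds are considered here, and "the series" means these few. Any claim that something is new, unique, unknown or untested is made for them only; others in the source may bear on it.

Three analogues on a shared core have been measured in an assay for binding affinity to dual specificity mitogen-activated protein kinase kinase 4 (Homo sapiens), read by KINOMEscan, tested at 100 nM; a higher number here means a weaker effect of the compound at the concentration tested, a lower number a stronger effect. Compound 1 `CCCS(=O)(=O)Nc1ccc(F)c(C(=O)c2n[nH]c3ncc(-c4ccccc4C)cc23)c1F` gives 7%. Compound 2 `CCCS(=O)(=O)Nc1ccc(F)c(C(=O)c2n[nH]c3ncc(-c4cccc(C)c4)cc23)c1F` gives 15%. For the measured compounds named here, compound 3 `CCCS(=O)(=O)Nc1ccc(F)c(C(=O)c2n[nH]c3ncc(-c4cccc(O)c4)cc23)c1F` gives 2.2%, the lowest of the three numbers; its step to compound 1 is within the scatter, a number 4.8 percentage points lower from compound 1 to compound 3 (within the scatter), and only the step from compound 2, a number 12.8 percentage points lower from compound 2 to compound 3 (beyond the scatter), lies beyond it. Compound 4 `CCCS(=O)(=O)Nc1ccc(F)c(C(=O)c2n[nH]c3ncc(-c4ccc(N)cc4)cc23)c1F` has not been measured. The change from compound 3 is this: 4-aminophenyl in place of 3-hydroxyphenyl on an aromatic carbon. The measured steps that bear on it are the exchanges of the ring placed on an aromatic carbon of the core: a number 4.8 percentage points lower from compound 1 to compound 3 (within the scatter) and a number 12.8 percentage points lower from compound 2 to compound 3 (beyond the scatter), with the third comparison being a number 8 percentage points higher from compound 1 to compound 2 (within the scatter). Going by the values given here, all three exchanges of this ring stayed within the scatter or only modestly beyond it, so no large step in this assay is expected from compound 3 to compound 4; the expected step is a number 2.8 percentage points higher from compound 3 to compound 4 (within the scatter), which lies within the scatter. Compound 4 is therefore estimated at 5%, with a range from 1% to 14%.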

Compound 4, a percentage reported as activity, at one concentration (the size of the read-out at that concentration, not a potency): 0.1%
Compound 4: the middle estimate sits 4.9 percentage points above what was measured; measured number outside the range, below it.
By their numbers in this assay, from the lowest: compounds 4, 3, 1 and 2 (each within the scatter of the next, the first and the last beyond it).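

In this assay the aryl ring on this aromatic carbon of the shared core accepts a change of both substituent and substitution pattern with no step beyond the scatter: 4-aminophenyl in place of 3-hydroxyphenyl gives a number 2.1 percentage points lower from compound 3 to compound 4 (within the scatter) and extends the tolerated set to a ring bearing an amino group. Against the two methylphenyl analogues the outcome divides, with a number 6.9 percentage points lower from compound 1 to compound 4 (within the scatter) but a number 14.9 percentage points lower from compound 2 to compound 4 (beyond the scatter), so compound 2 now lies beyond the scatter from both compound 3 and compound 4, while compound 1 lies within it of every other compound. Nothing available here explains these steps.

Compound 4 differs from compound 3 in both the atom of the ring substituent and its location, so the two contributions stay unseparated; an amine in the place of the hydroxy of compound 3, or a hydroxy in the place of the amine of compound 4, would divide them. On these data alone, whether this tolerance extends to a carboxylic acid or a longer chain on the same ring also remains open.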